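A few compounds are considered here, and "the series" means these few. Any claim that something is new, unique, unknown or untested is made for them only; others in the source may bear on it.

Of the compounds shown here, three built on one shared core have been measured so far. In a functional assay on ACHN cells (Homo sapiens) for inhibition, read by sulforhodamine B assay, with a stated time of 48 h, tested at 10 uM (a lower number here means less inhibition, a higher number more inhibition at the concentration tested (going by the name of the read-out)), compound 1 `Fc1ccc(-c2cn3ccnc3c(-c3ccc4ncn(C5CCCCC5)c4c3)n2)cc1` gives 9.02%. Compound 2 `CC(=O)c1ccc(-c2cn3ccnc3c(-c3ccc4ncn(C5CCCCC5)c4c3)n2)cc1` gives 4.32% in this assay, and compound 3 `COc1ccccc1-c1cn2ccnc2c(-c2ccc3ncn(C4CCCCC4)c3c2)n1` gives 4.48%. Among these three numbers compound 3 stands second highest; its nearest neighbour is compound 2, with a step of a number 0.2 percentage points higher from compound 2 to compound 3 (within the scatter), and its furthest is compound 1, with a step of a number 4.5 percentage points lower from compound 1 to compound 3 (within the scatter). The remaining measured step, a number 4.7 percentage points lower from compound 1 to compound 2 (within the scatter), also stays within the scatter, so the three numbers cannot be told apart. The next compound, compound 4 `FC(F)(F)c1cccc(-c2cn3ccnc3c(-c3ccc4ncn(C5CCCCC5)c4c3)n2)c1`, differs from compound 3 in one place: 3-(trifluoromethyl)phenyl in place of 2-methoxyphenyl on an aromatic carbon. The measured steps that bear on this change are the two that also exchange the group at the same aromatic carbon, a number 4.5 percentage points lower from compound 1 to compound 3 (within the scatter) and a number 0.2 percentage points higher from compound 2 to compound 3 (within the scatter), and both lie within the scatter. Hence the expected step in this assay is a number 0.5 percentage points higher from compound 3 to compound 4 (within the scatter), nothing beyond the scatter. Compound 4 is therefore estimated at 5%, with a range from -5% to 15%.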

Compound 4, a percentage reported as inhibition, at one concentration (the size of the read-out at that concentration, not a potency): 0.3%
Estimate against measurement, compound 4: 4.7 percentage points above; measured number inside the range.
By their numbers in this assay, from the lowest: compounds 4, 2, 3 and 1 (each within the scatter of the next).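

In this assay the exchange at this aromatic carbon now extends to 3-(trifluoromethyl)phenyl, and its steps are a number 4.2 percentage points lower from compound 3 to compound 4 (within the scatter) and a number 4 percentage points lower from compound 2 to compound 4 (within the scatter) and a number 8.7 percentage points lower from compound 1 to compound 4 (within the scatter). Even the largest of these stays within the scatter, so the four aryl groups at this position cannot be told apart in this read-out, and no order can be drawn among them. Nothing measured here offers an explanation for these numbers.

The compounds shown leave open whether an amine or a carboxylic acid on the aromatic ring at this carbon would give a number beyond the scatter. They also leave open whether any change elsewhere on the shared core would do so, and how these compounds behave at other concentrations.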